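The compounds below may be only part of what the source reports. "The series", "measured", "known", "first", "only" and "open" are said of these compounds alone.

Working notes on a small series examined for cytotoxicity.

Compound 1 `CNC1=C([N+](=O)[O-])C(c2ccc(N3CCN(c4ccnc5cc(Cl)ccc45)CC3)cc2)c2cc(Cl)ccc2O1` is the reference point. In an ADME assay on Vero cells (Chlorocebus sabaeus) for cytotoxicity, read by MTT assay, with a stated time of 72 h (on this read-out lower numbers stand for higher toxicity in this test and higher numbers for lower toxicity in this test), compound 1 gives 74500 nM. Compound 2 `CNC1=C([N+](=O)[O-])C(c2ccc(N3CCN(c4ccnc5cc(Cl)ccc45)CC3)cc2)c2cc(Br)ccc2O1` differs from compound 1 only by bromo in place of chloro on an aromatic carbon. In this assay compound 2 gives 88600 nM; the change produced a 1.2-fold higher number from compound 1 to compound 2 (0.08 log units; within the scatter), so the two compounds are indistinguishable on this read-out.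

Compound 3 `CNC1=C([N+](=O)[O-])C(c2ccc(N3CCCN(c4ccnc5cc(Cl)ccc45)CC3)cc2)c2cc(Cl)ccc2O1` carries a different core from compound 1; the difference between the two cores is not broken down here. In this assay compound 3 gives 77000 nM. The values of compound 3 and compound 1 lie within the scatter of each other, as do those of compound 3 and compound 2, so the core change gives no separation on this read-out.

Compound 4 `CNC1=C([N+](=O)[O-])C(c2ccc(N3CCCN(c4ccnc5cc(Cl)ccc45)CC3)cc2)c2cc(Br)ccc2O1` stands to compound 3 as compound 2 stands to compound 1: the change is bromo in place of chloro on an aromatic carbon, the same change at the same place. Because the earlier step was a 1.2-fold higher number from compound 1 to compound 2 (0.08 log units; within the scatter), a step of similar size is expected here, and the expectation for compound 4 is a step of a 1.1-fold higher number from compound 3 to compound 4 (0.06 log units; within the scatter) relative to compound 3 in this assay. On that basis compound 4 is estimated at 88000 nM in this assay, with an expected range from 55000 nM to 140000 nM.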

Compound 4, half-maximal cytotoxic concentration: > 200000 nM
Compound 4: a limit, no number; the forecaster's own chance of this, stated with the estimate: 10%; at least 2.2-fold (0.35 log units) between middle value and limit.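

On the core of compound 3, in this assay, bromo in place of chloro on an aromatic carbon gives an at least 2.5-fold higher number from compound 3 to compound 4 (0.41 log units; beyond the scatter), a step beyond the scatter, whereas the same change on the core of compound 1 gives a 1.2-fold higher number from compound 1 to compound 2 (0.08 log units; within the scatter), a step within it. This shows that a change with no measurable effect on one core can be followed by a clear rise in the number on the other core, but it does not show that the two steps differ: the same change on two cores in this assay, a 1.2-fold higher number (0.08 log units; within the scatter) from compound 1 to compound 2 and an at least 2.5-fold higher number (0.41 log units; beyond the scatter) from compound 3 to compound 4; the limit leaves it open whether they differ Compound 4 gives > 200000 nM, which is a limit of the assay and not a number, so the full size of the step on this core remains unknown, and only one compound in the series sits there: the limit of > 200000 nM in this assay, at which 1 of the 4 values shown sits.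

Going by these compounds, only chloro and bromo appear here, on two cores, so it stays open whether fluoro, iodo or a nitrile at the same place would give a step of either kind. Also open, on these data alone, is whether the difference seen between the two steps would appear again with an amine or a carboxylic acid at that place, or would be confined to the pair of compound 3 and compound 4.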